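Compound 4: 3-chlorophenyl for 2-fluorophenyl

A few compounds are considered here, and "the series" means these few. Any claim that something is new, unique, unknown or untested is made for them only; others in the source may bear on it.

In a functional assay on MV4-11 cells (Homo sapiens) for antiproliferative activity, read by CCK-8 assay, with a stated time of 72 h (a higher number here means a weaker inhibitor, a lower number a stronger inhibitor), compound 1 (`Cn1cc(-c2ccccc2F)c2cc(C(=O)NCc3ccc(C(=O)Nc4ccccc4N)cc3)[nH]c2c1=O`) gives 230 nM as its half-maximal inhibitory concentration, the second highest of the three numbers in hand. Compound 2 (`Cn1cc(-c2ccccc2Oc2ccccc2)c2cc(C(=O)NCc3ccc(C(=O)NO)cc3)[nH]c2c1=O`) sits higher with 570 nM on the same read-out, and compound 3 (`Cn1cc(-c2ccccc2Oc2ccccc2)c2cc(C(=O)NCCCCCC(=O)Nc3ccccc3N)[nH]c2c1=O`) sits lower with 70 nM on it. Both gaps to compound 1 lie beyond the scatter. Compounds 2 and 3 each differ from compound 1 in more than one place. Among the measured compounds shown here, no measured pair therefore isolates a single change, and nothing measured speaks to this aryl group alone.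

Compound 4 (`Cn1cc(-c2cccc(Cl)c2)c2cc(C(=O)NCc3ccc(C(=O)Nc4ccccc4N)cc3)[nH]c2c1=O`) departs from compound 1 in one group: 3-chlorophenyl in place of 2-fluorophenyl on an aromatic carbon of a six-membered aromatic ring with 1 nitrogen (3-chlorophenyl in place of 2-fluorophenyl on an aromatic carbon). The rest of the structure stays as it is.

Without a precedent, the working expectation in this assay is no step beyond the scatter and no favoured direction, with compound 1 at 230 nM as the only close anchor. The expected step is a 1.2-fold lower number from compound 1 to compound 4 (0.06 log units; within the scatter) as an estimate. The range is kept wide for lack of any direct comparison. For compound 4 the estimated value is 200 nM with an expected range from 70 nM to 600 nM as its limits of belief.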

Compound 4, half-maximal inhibitory concentration: 190 nM
Estimate against measurement, compound 4: 1.1-fold (0.02 log units) above; low and high end bracket the measured number.
By their numbers in this assay, from the lowest: compound 3; then compounds 4 and 1 (each within the scatter of the next); then compound 2.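

In this assay the series gains its first comparison that isolates one place, and it reads as a 1.2-fold lower number from compound 1 to compound 4 (0.08 log units; within the scatter). On this read-out, 3-chlorophenyl and 2-fluorophenyl on this aromatic carbon cannot be told apart, so this one exchange of aryl groups, with the same heavy-atom count on both sides, leaves the antiproliferative read-out within the scatter. The change alters both the halogen and where it sits on the phenyl ring, so the pair cannot separate these two features, and no independent measurement bears on the result.

On these data alone, whether the flat response holds for an unsubstituted phenyl, a methoxyphenyl, an aminophenyl or a pyridine ring at this carbon remains open, as does the effect of moving a single halogen around the phenyl ring while keeping the halogen the same. Compounds 2 and 3 differ from compounds 1 and 4 in more than one place, so their gaps to those two compounds cannot be read as the effect of any single group, including the aryl group at this position.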